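This account rests on a few compounds, and the source may have more. Where it says the series, first, only, none or still open, it means among the compounds named here.

Measured so far in a functional assay on K562 cells (Homo sapiens) for cytotoxicity; a higher number here means a weaker inhibitor of growth, a lower number a stronger inhibitor of growth:
compound 1 `OCCC#Cc1ccccc1C#Cc1ccccc1`, 11000 nM;
compound 2 `OCCCCC#Cc1ccccc1C#Cc1ccccn1`, 29000 nM;
compound 3 `OCCCCC#Cc1ccccc1C#Cc1ccccc1C(F)(F)F`, 1100 nM.

Compound 2 gives the highest number of the three and is thus the weakest inhibitor of growth among them; the nearest value belongs to compound 1, the furthest to compound 3, and both gaps lie beyond the usual scatter. Compound 4 `OCCCCC#Cc1ccccc1C#Cc1cccc(O)c1` has not yet been measured in this assay. It differs from compound 2 in one place: 3-hydroxyphenyl in place of pyridin-2-yl on a triple-bonded carbon. Compound 1 and compound 3, which both carry a ring of carbon only on the triple-bonded carbon, give lower numbers than compound 2, though each also differs from it elsewhere, so no single step can be read off. A moderate move toward a lower number is therefore expected, as a 3.6-fold lower number from compound 2 to compound 4 (0.56 log units; beyond the scatter). The estimate for compound 4 is 8000 nM, with a range from 2500 nM to 25000 nM.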

Compound 4, concentration for 50% growth inhibition: 19200 nM
Beside the measured number, compound 4's estimate is 2.4-fold (0.38 log units) below it, and the stated range covers the measured number.
By their numbers in this assay, from the lowest: compound 3; then compounds 1, 4 and 2 (each within the scatter of the next, the first and the last beyond it).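

In this assay, among the compounds shown here, 3-hydroxyphenyl in place of pyridin-2-yl on a triple-bonded carbon gives a 1.5-fold lower number from compound 2 to compound 4 (0.18 log units; within the scatter), the first change here that can be read in one place. Trading a ring with one nitrogen for a carbon-only ring with a hydroxyl, which adds a hydrogen-bond donor, therefore does not separate these two compounds. No measurement shown here explains this result. Still open, going by these compounds, is how a methoxy group in place of the hydroxyl would read at this position, and whether an amine or a carboxylic acid on the ring would shift the number.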